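Swapping a Sulfonamide for an Acetamide on the Shared Core

The compounds below may be only part of what the source reports. "The series", "measured", "known", "first", "only" and "open" are said of these compounds alone.

Among the compounds with values here, compound 2 `NS(=O)(=O)c1cccc(Nc2nccc(-c3cccnc3)n2)c1` gives 200 nM in a functional assay for inhibition, with Homo sapiens as the target (a lower number here means a stronger inhibitor, a higher number a weaker inhibitor), and holds the lowest of the two numbers so far; its nearest neighbour is compound 1 `CC(=O)c1cccc(Nc2nccc(-c3cccnc3)n2)c1`, which gives 4100 nM. The change from compound 2 to compound 3 `CC(=O)Nc1cccc(Nc2nccc(-c3cccnc3)n2)c1` is acetamido in place of sulfamoyl on an aromatic carbon. Within the data shown here, the only measured step, a 21-fold lower number from compound 1 to compound 2 (1.31 log units; beyond the scatter), involves the group that now leaves but not the one that enters, so it offers guidance only by analogy. Compound 3 is therefore expected to land between the two, with a 4.5-fold higher number from compound 2 to compound 3 (0.65 log units; beyond the scatter) estimated at 900 nM, within 150 nM to 4500 nM.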

Compound 3, half-maximal inhibitory concentration: 3600 nM
Compound 3: middle estimate off by 4.0-fold (0.60 log units), on the low side; low and high end bracket the measured number.
By their numbers in this assay, from the lowest: compound 2; then compounds 3 and 1 (each within the scatter of the next).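

In this assay, acetamido does not stand in for sulfamoyl at this position, giving an 18-fold higher number from compound 2 to compound 3 (1.26 log units; beyond the scatter) and so a second large step away from compound 2. Acetamido and acetyl cannot be told apart, with a 1.1-fold lower number from compound 1 to compound 3 (0.06 log units; within the scatter) and a result within the scatter, so among these three groups only sulfamoyl stands out. Nothing available explains this difference.

The compounds shown leave open whether the sulfonyl part alone would suffice, as a methylsulfonyl group might show. Going by these compounds, how a carboxylic acid or a simple amine would fare at this place also remains unknown.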